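Compound 4 and the hydroxyl-free side of the series

This account rests on a few compounds, and the source may have more. Where it says the series, first, only, none or still open, it means among the compounds named here.

Measured in an ADME assay on microsomes from liver (Rattus norvegicus) for metabolic stability, with a stated time of 60 min, tested at 1 uM; a higher number here means that more of the compound is left, a lower number that less of the compound is left:
- Compound 1 `COc1cc(-c2cnn3cc(OC)c(C(C)(C)O)nc23)ccn1`: 92%
- Compound 2 `COc1cc(-c2cnn3cc(OC)c(C)nc23)ccn1`: 13%
- Compound 3 `COc1cc(-c2cnn3cc(OC)c(N(C)C)nc23)ccn1`: 3%

Compound 3 stands close to one neighbour and far from the other. The data show a number 10 percentage points lower from compound 2 to compound 3 (within the scatter), and also a number 89 percentage points lower from compound 1 to compound 3 (beyond the scatter).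

The next compound, compound 4 `COc1cc(-c2cnn3cc(OC)c(C4CCCC4)nc23)ccn1`, has not yet been measured in this assay. It carries cyclopentyl in place of dimethylamino on an aromatic carbon.

For the measured compounds named here, no measured step brings in cyclopentyl, so the evidence is indirect. The large changes both involve the loss of 1-hydroxy-1-methylethyl: besides the drop to compound 3, there is a number 79 percentage points lower from compound 1 to compound 2 (beyond the scatter). Cyclopentyl does not restore that group, and exchanging methyl for dimethylamino gave a number 10 percentage points lower from compound 2 to compound 3 (within the scatter). No change beyond the scatter is therefore expected.

The expected step is a number 3 percentage points higher from compound 3 to compound 4 (within the scatter). For compound 4 the estimate is 6%, with an expected range from 0% to 20%.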

Compound 4, percent of the compound remaining: 7%
For compound 4 the middle estimate is 1 percentage points below the measured one; the range from low to high includes it.
By their numbers in this assay, from the lowest: compounds 3, 4 and 2 (each within the scatter of the next); then compound 1.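

In this assay, cyclopentyl at this aromatic carbon gives a number 4 percentage points higher from compound 3 to compound 4 (within the scatter) and, set against methyl, a number 6 percentage points lower from compound 2 to compound 4 (within the scatter), so a five-membered ring of carbon only, with 5 heavy atoms, does not separate from dimethylamino or methyl. The gap to the 1-hydroxy-1-methylethyl group stays wide, with a number 85 percentage points lower from compound 1 to compound 4 (beyond the scatter), and among these four compounds only compound 1 stands apart, now against three different replacements rather than two. No measurement shown here accounts for either the closeness of the three or the gap to compound 1.

It remains open whether the hydroxyl itself or the branched carbon bearing it goes with the gap, since a 1-methoxy-1-methylethyl or a hydroxymethyl group does not appear among these compounds. A 1-hydroxycyclopentyl group at this position, which would join the ring of compound 4 to the hydroxyl of compound 1, is also absent.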